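A few compounds are considered here, and "the series" means these few. Any claim that something is new, unique, unknown or untested is made for them only; others in the source may bear on it.

Measured in a physicochemical assay for lipophilicity; a lower number here means a more polar compound, a higher number a more lipophilic compound:
Compound 1 `C=C(c1cccc2ccccc12)C1CCC2(CC1)COC(Nc1ccccc1)OO2`: 5.59
Compound 2 `C=C(c1cccc2ccccc12)C1CCC2(CC1)COC(Nc1cccc(C(F)(F)F)c1)OO2`: 6.51
Compound 3 `C=C(c1ccc2ccccc2c1)C1CCC2(CC1)COC(Nc1ccccc1)OO2`: 5.59

Level with compound 1, compound 3 stands at 5.59, and the two share the lowest number of the three. Compound 4 `C=C(c1ccc2ccccc2c1)C1CCC2(CC1)COC(Nc1ccc(OC)cc1)OO2` differs from it by methoxy in place of hydrogen on an aromatic carbon, which is methoxy in place of hydrogen on an aromatic carbon.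

The closest measured change also replaces hydrogen on an aromatic carbon, but with trifluoromethyl, giving a number 0.92 log units higher from compound 1 to compound 2 (beyond the scatter). The swap of naphthalen-1-yl for naphthalen-2-yl gave no change at the digits printed from compound 1 to compound 3 (within the scatter), but it lies elsewhere in the molecule. Methoxy is a different group, so the trifluoromethyl step is only a loose guide, and no clear shift in this assay is expected beyond the scatter. The expected step is a number 0.04 log units lower from compound 3 to compound 4 (within the scatter). For compound 4 the estimated value is 5.55, within an expected range of 5.25 to 5.95.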

Compound 4, partition coefficient: 5.46
Compound 4: the middle estimate sits 0.09 log units above what was measured; low and high end bracket the measured number.
By their numbers in this assay, from the lowest: compounds 4, 1 and 3 (each within the scatter of the next); then compound 2.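

Methoxy in place of hydrogen on an aromatic carbon, para to a large group, gives a number 0.13 log units lower from compound 3 to compound 4 (within the scatter) in this assay. So a new group on this aromatic ring need not move the number beyond the scatter, unlike trifluoromethyl, which gave a number 0.92 log units higher from compound 1 to compound 2 (beyond the scatter). No measurement here accounts for the difference between these two steps.

As far as these compounds go, it remains open whether an amine, a carboxylic acid or a longer chain such as butoxy at this place would also stay within the scatter. From the compounds shown here alone, whether methoxy behaves the same alongside naphthalen-1-yl is also open.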